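The compounds below may be only part of what the source reports. "The series", "measured", "known", "first", "only" and "open" are said of these compounds alone.

Measured so far in a functional assay on SK-BR-3 cells (Homo sapiens) for antiproliferative activity, read by MTT assay, with a stated time of 72 h; a lower number here means a stronger inhibitor, a higher number a weaker inhibitor:
compound 1 `C/C=C1/[C@H](O[C@@H]2O[C@H](CO)[C@@H](O)[C@H](O)[C@H]2O)OC=C(C(=O)OC)[C@H]1CC(=O)OCc1ccco1` gives > 15000 nM
compound 2 `C/C=C1/[C@H](O[C@@H]2O[C@H](CO)[C@@H](O)[C@H](O)[C@H]2O)OC=C(C(=O)O)[C@H]1CC(=O)OC` gives > 20000 nM
compound 3 `C#CCOC(=O)C[C@@H]1C(C(=O)OC)=CO[C@@H](O[C@@H]2O[C@H](COC(C)=O)[C@@H](OC(C)=O)[C@H](OC(C)=O)[C@H]2OC(C)=O)/C1=C/C` gives > 15000 nM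

Compound 1 is known in this assay only as a limit, not a number. Compound 2 likewise is known only as a limit. Compound 3 is also known only as a limit. Among the compounds with values here, compound 1 therefore stands where the whole small set stands: no compound has a number, two sit at the limit of > 15000 nM in this assay, at which 2 of the 3 values shown sit, and one at the limit of > 20000 nM in this assay, at which 1 of the 3 values shown sits, and nothing here separates one from another. Compound 1 and compound 3 carry different esters on the side chain, and both show only a limit.

Compound 4 `C/C=C1/[C@H](O[C@@H]2O[C@H](CO)[C@@H](O)[C@H](O)[C@H]2O)OC=C(C(=O)OC)[C@H]1CC(=O)OCc1ccc(OC)c(OC)c1` is the next entry. It differs from compound 1 in one place: 3,4-dimethoxyphenyl in place of furan-2-yl on a saturated chain carbon bound to an oxygen next to a carbonyl group. Within the data shown here, no measured pair that differs in one place exists in this set, so no step size can be read from data. With compound 1 at > 15000 nM and every other measured compound at a limit as well, the step from compound 1 to compound 4 is expected to be none beyond the scatter, a step that the limit leaves unreadable from compound 1 to compound 4. Compound 4 is accordingly estimated at 20000 nM in this assay, within a range of 8000 nM to 60000 nM, most likely again reported only as a limit.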

Compound 4, half-maximal inhibitory concentration: > 15000 nM
Compound 4: only a limit was reported (the forecaster's own chance of this, stated with the estimate: 75%); the middle value does not contradict the limit.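

Compound 1 and compound 4 are known only as limits in this assay, so no step can be read for 3,4-dimethoxyphenyl in place of furan-2-yl; both sit at the same limit: the limit of > 15000 nM in this assay, at which 3 of the 4 values shown sit.

The compounds shown leave open whether any change to the shared core or its side chain gives a measurable value in this assay.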